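This account rests on a few compounds, and the source may have more. Where it says the series, first, only, none or still open, it means among the compounds named here.

Measured so far in a functional assay (strain AB) with Danio rerio as the target, read by microscopy, with a stated time of 1 h; on this read-out lower numbers stand for an effect already at smaller amounts and higher numbers for an effect only at larger amounts of compound:
- compound 1 `CC(C)(C)OC(=O)CCCN1CCc2c(sc(NC(=O)Nc3ccc(Cl)cc3)c2C(N)=O)C1`: 560 nM
- compound 3 `CCN1CCc2sc(NC(=O)Nc3ccc(Cl)cc3)c(C(N)=O)c2CC1`: 5800 nM
- compound 2 `CCN1CCc2c(ccc(NC(=O)Nc3ccc(Cl)cc3)c2C(N)=O)C1`: a limit, > 25000 nM

Compound 1 holds the lowest of the two numbers in this assay. Compound 3 gives 5800 nM, a gap to compound 1 that lies beyond the scatter. For compound 2 this assay reports only a limit and no number, > 25000 nM. Of the three results, one is the limit of > 25000 nM in this assay, at which 1 of the 3 values shown sits. Compound 2 and compound 3 are not linked to compound 1 by any single change, so only their values can be set side by side.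

Compound 4 `CCCN1CCc2c(sc(NC(=O)Nc3ccc(Cl)cc3)c2C(N)=O)C1` is the next compound, not yet measured in this assay. Relative to compound 1 the change is hydrogen in place of tert-butoxycarbonyl on a saturated chain carbon, three bonds along the chain from an amine nitrogen in a ring. The tert-butoxycarbonyl is the only part that leaves; the rest of compound 1 stays. The step of a 2.7-fold higher number from compound 1 to compound 4 (0.43 log units; beyond the scatter) is expected to be modest and toward a higher number, at the edge of the scatter rather than well past it. Compound 4 is estimated at 1500 nM, within a range from 300 nM to 8000 nM.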

Compound 4, half-maximal effective concentration: 3500 nM
The estimate for compound 4 lay 2.3-fold (0.37 log units) below the measured number; the measured number falls inside the stated range.
By their numbers in this assay, from the lowest: compound 1; then compounds 4 and 3 (each within the scatter of the next). At a limit, above all of these: compound 2.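

Among these compounds, this is the first single change that can be read: in this assay, hydrogen in place of tert-butoxycarbonyl at the end of the chain on the ring nitrogen gives a 6.3-fold higher number from compound 1 to compound 4 (0.80 log units; beyond the scatter). The tert-butoxycarbonyl therefore counts at this position, since the lower number goes with the 3-(tert-butoxycarbonyl)propyl chain rather than the plain propyl chain, yet without that group compound 4 still gives a number, 3500 nM, and not a limit. No measurement shown accounts for the size of this step.

The compounds shown do not tell whether the lower number needs the whole tert-butoxycarbonyl or only part of it. A carboxylic acid or a methyl ester at the chain end, or a longer alkyl chain, would separate these readings.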